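The source may hold more compounds than are shown below. What is called first, only, known or untested is meant among the compounds shown, and "the series" means these compounds.

Among the measured compounds shown here, compound 3 `FC(F)(F)c1ccc2c(c1)C=C(CC1CN=CN1)CC2` stands highest of the three compounds measured so far in an assay on isolated protein for binding affinity to Adrenergic receptor alpha-1 (Rattus norvegicus), read by radioligand binding, in the presence of a further agent that is not named here (on this read-out higher numbers stand for weaker inhibition and lower numbers for stronger inhibition), giving 1260 nM. Compound 1 `C1=NCC(CC2=Cc3ccccc3CC2)N1`, the unsubstituted parent, gives 398 nM in this assay, and compound 2 `Fc1ccc2c(c1)C=C(CC1CN=CN1)CC2` gives 251 nM. Both neighbours lie below compound 3, and the steps leading to it were a 3.2-fold higher number from compound 1 to compound 3 (0.50 log units; beyond the scatter) and a 5.0-fold higher number from compound 2 to compound 3 (0.70 log units; beyond the scatter). Between the two lower compounds the change was a 1.6-fold lower number from compound 1 to compound 2 (0.20 log units; within the scatter).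

Compound 4 `COc1ccc2c(c1)C=C(CC1CN=CN1)CC2` is the compound now awaiting measurement. It differs from compound 3 by methoxy in place of trifluoromethyl on an aromatic carbon. For the measured compounds named here, the steps that bear on this change are the two that placed the trifluoromethyl group at the same aromatic carbon, each raising the number by a modest amount beyond the scatter. Removing that group is therefore expected to bring the number back down toward what compound 1 and compound 2 gave. No methoxy group has been measured on this shared core, so how far the return goes is uncertain. The expected step is a 3.2-fold lower number from compound 3 to compound 4 (0.50 log units; beyond the scatter), a modest lowering. Compound 4 is accordingly estimated to give 400 nM in this assay, within a range from 150 nM to 1100 nM.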

Compound 4, inhibition constant: 2510 nM
Beside the measured number, compound 4's estimate is 6.3-fold (0.80 log units) below it; measured number outside the range, above it.
By their numbers in this assay, from the lowest: compounds 2 and 1 (each within the scatter of the next); then compounds 3 and 4 (each within the scatter of the next).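

In this assay methoxy at this aromatic carbon does not bring the number back to the level of the other two compounds, for the data show a 6.3-fold higher number from compound 1 to compound 4 (0.80 log units; beyond the scatter) and a 10-fold higher number from compound 2 to compound 4 (1.00 log units; beyond the scatter) while the change from trifluoromethyl to methoxy amounts to only a 2.0-fold higher number from compound 3 to compound 4 (0.30 log units; within the scatter) and so does not separate the two groups. Methoxy carries a hydrogen-bond acceptor and trifluoromethyl carries none, yet compound 3 and compound 4 stand together above compound 1 and compound 2, and across these four compounds fluoro is the one substituent that goes against the rise seen with the other two, its step being a 1.6-fold lower number from compound 1 to compound 2 (0.20 log units; within the scatter) and within the scatter. No measurement given here speaks to what lies behind this shared rise.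

The compounds shown leave open whether an amine or a hydroxyl group at this aromatic carbon would fall with hydrogen and fluoro or with methoxy and trifluoromethyl, and whether a longer chain such as ethoxy would move the number further. They also leave open whether methoxy would give a similar number at another carbon of this aromatic ring.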